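A few compounds are considered here, and "the series" means these few. Any claim that something is new, unique, unknown or untested is made for them only; others in the source may bear on it.

Compound 1 `CC(Sc1nnc(-c2ccncc2)s1)C(=O)NCc1ccccc1Cl` gives > 50000 nM. Compound 2 `O=C(CCSc1nnc(-c2ccncc2)s1)Nc1ccccc1` gives > 50000 nM. Compound 3 `O=C(CCSc1nnc(-c2ccncc2)s1)Nc1ccc(Cl)cc1Cl` gives > 50000 nM.

In an ADME assay on HepG2 cells (Homo sapiens) for cytotoxicity, with a stated time of 3 days (a higher number here means that more compound is tolerated, a lower number that less compound is tolerated), the value of compound 1 is a limit, not a number. The value of compound 2 is a limit as well. The value of compound 3 is likewise a limit. All three sit at the limit of > 50000 nM in this assay, at which 3 of the 3 values shown sit, so compound 1 stands with the others at the edge of what this assay reports. Within the data shown here, the one measured change on the amide-type nitrogen, a step that the two limits leave unreadable from compound 2 to compound 3, cannot be read between two limits.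

Compound 4 `CC(Sc1nnc(-c2ccncc2)s1)C(=O)Nc1ccc(Cl)cc1` differs from compound 1 by 4-chlorophenyl in place of 2-chlorobenzyl on an amide-type nitrogen. The step is expected to be a step that the limit leaves unreadable from compound 1 to compound 4, nothing beyond the scatter, since every shown value rests at the limit of > 50000 nM in this assay, at which 3 of the 3 values shown sit. Compound 4 is therefore estimated at 70000 nM, within 35000 nM to 200000 nM, most likely reported again only as a limit.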

Compound 4, half-maximal cytotoxic concentration: > 50000 nM
Compound 4 was reported as a limit; the forecaster's own chance of this, stated with the estimate: 85%; the middle value does not contradict the limit.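

No step can be read between compound 1 and compound 4, since both values are limits in this assay: the limit of > 50000 nM in this assay, at which 4 of the 4 values shown sit.

The compounds shown leave open how much of each is actually tolerated in this assay.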